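The source may report more compounds than this note shows. Statements on the series, on what has been measured and on what is new or still open speak of the compounds shown alone.

Within this series, in a functional assay on PC-3 cells (Homo sapiens) for cytotoxicity, read by MTT assay, with a stated time of 72 h (on this read-out lower numbers stand for stronger inhibition and higher numbers for weaker inhibition), compound 1 `O=C(Nc1ccc(Oc2ccnc3[nH]ccc23)cc1)c1cc(-c2ccc(Cl)cc2)ncn1` gives 15600 nM, while compound 2 `COc1ccc(-c2cc(C(=O)Nc3ccc(Oc4ccnc5[nH]ccc45)c(F)c3)ncn2)cc1` gives 2570 nM; compound 2 holds the lower of the two numbers, and its gap to compound 1 is beyond the scatter. Compound 3 `O=C(Nc1ccc(Oc2ccnc3[nH]ccc23)c(F)c1)c1cc(-c2ccc(Cl)cc2)ncn1` awaits measurement in this assay. It differs from compound 2 by chloro in place of methoxy on an aromatic carbon. Compound 1 also carries 4-chlorophenyl and gives the higher number, so the expected step of a 2.7-fold higher number from compound 2 to compound 3 (0.44 log units; beyond the scatter) is a modest rise, toward weaker inhibition. For compound 3 the estimated value is 7000 nM, with a range from 2500 nM to 20000 nM.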

Compound 3, half-maximal inhibitory concentration: 3200 nM
Compound 3: the middle estimate sits 2.2-fold (0.34 log units) above what was measured, and the stated range covers the measured number.
By their numbers in this assay, from the lowest: compounds 2 and 3 (each within the scatter of the next); then compound 1.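

In this assay, methoxy and chloro on the aromatic carbon para to a large group are not told apart (a 1.2-fold higher number from compound 2 to compound 3 (0.10 log units; within the scatter)). With 4-chlorophenyl present in both compounds, fluoro in place of hydrogen gives a step beyond the scatter (a 4.9-fold lower number from compound 1 to compound 3 (0.69 log units; beyond the scatter)). No measurement at hand explains either step.

Open, from the compounds shown here alone, is whether an amine or a carboxylic acid on that aromatic carbon would stay within the scatter of these two compounds. Also open, going by these compounds, is whether the fluoro step carries over to the 4-methoxyphenyl compounds.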